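A few compounds are considered here, and "the series" means these few. Any claim that something is new, unique, unknown or untested is made for them only; others in the source may bear on it.

The compounds share one core and differ in the substituted phenyl group on a saturated ring carbon. In a functional assay (muscle tissue) with Cavia porcellus as the target (on this read-out lower numbers stand for an effect already at smaller amounts and higher numbers for an effect only at larger amounts of compound), compound 1 `COC(=O)C1=C(C)N=C(C)/C(=C(\O)OC)C1c1cc(Cl)cc(Cl)c1` gives 93.3 nM, compound 2 `COC(=O)C1=C(C)N=C(C)/C(=C(\O)OC)C1c1cccc(N)c1` gives 2000 nM and compound 3 `COC(=O)C1=C(C)N=C(C)/C(=C(\O)OC)C1c1ccc(Br)cc1` gives 540 nM, which makes compound 3 the second highest of the three numbers.

The next step leads to compound 4 `COC(=O)C1=C(C)N=C(C)/C(=C(\O)OC)C1c1c(Cl)cccc1Cl`, with this change: 2,6-dichlorophenyl in place of 4-bromophenyl on a saturated ring carbon. Within the data shown here, compound 1 is the only measured dichlorophenyl compound, so the closest precedent is a 5.8-fold higher number from compound 1 to compound 3 (0.76 log units; beyond the scatter). The other steps, a 3.7-fold lower number from compound 2 to compound 3 (0.57 log units; beyond the scatter) and a 21-fold higher number from compound 1 to compound 2 (1.33 log units; beyond the scatter), show how widely the number moves with the phenyl group. Among the measured compounds shown here, no measured compound carries the 2,6-dichlorophenyl group, so this chlorine placement is untested and the precedent is only partial.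

A modest step towards a lower number in this assay is expected, close in size to the gap between compound 3 and compound 1. The estimate for compound 4 is 120 nM, with an expected range of 20 nM to 600 nM. This estimate corresponds to an expected 4.5-fold lower number from compound 3 to compound 4 (0.65 log units; beyond the scatter).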

Compound 4, half-maximal effective concentration: 1.91 nM
The estimate for compound 4 lay 63-fold (1.80 log units) above the measured number; measured number outside the range, below it.
By their numbers in this assay, from the lowest: compound 4; then compound 1; then compound 3; then compound 2.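

Moving the chlorines alone, with 2,6-dichlorophenyl in place of 3,5-dichlorophenyl, gives a 49-fold lower number from compound 1 to compound 4 (1.69 log units; beyond the scatter) in this assay, so at this saturated ring carbon the placement of the chlorines on the phenyl group, and not just their presence, strongly shifts the number. Among these compounds, the 2,6-dichlorophenyl group also stands far from the other two phenyl groups, with a 280-fold lower number from compound 3 to compound 4 (2.45 log units; beyond the scatter) and a 1000-fold lower number from compound 2 to compound 4 (3.02 log units; beyond the scatter), which puts compound 4 lowest of the four and exceeds every step among the earlier compounds. Nothing available accounts for why this placement has so large an effect.

As far as these compounds go, whether a single chlorine on the phenyl group is enough remains open. So does whether methyl or fluorine in place of both chlorines of the 2,6-dichlorophenyl group would keep the number this low.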